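The source may hold more compounds than are shown below. What is called first, only, known or untested is meant among the compounds shown, and "the series" means these compounds.

Working notes on the series.

Compound 1 `COc1ccc(C(=O)/C(=C/c2ccc(Cl)cc2Cl)CCOC(C)=O)cc1` gives 83400 nM in a functional assay on MCF7 cells (Homo sapiens) for inhibition, read by XTT assay, with a stated time of 48 h; on this read-out higher numbers stand for weaker inhibition and lower numbers for stronger inhibition. Compound 3 `COc1ccc(C(=O)/C(=C/c2ccc(Cl)cc2Cl)CC(C)C)cc1` carries the change isopropyl in place of acetoxymethyl on a saturated chain carbon bound to a double-bonded chain carbon and reaches only a limit of this assay, > 100000 nM. That step, an at least 1.1-fold higher number from compound 1 to compound 3 (0.07 log units; that floor lies within the scatter), cannot be sized further because the limit of > 100000 nM in this assay, at which 2 of the 3 values shown sit, caps it. Compound 2 `COc1ccc(C(=O)/C(=C/c2ccc([N+](=O)[O-])cc2)CCOC(C)=O)cc1` differs from compound 1 in its core by 4-nitrophenyl in place of 2,4-dichlorophenyl on a double-bonded chain carbon bound to a double-bonded chain carbon; the step of an at least 1.1-fold higher number from compound 1 to compound 2 (0.07 log units; that floor lies within the scatter) is likewise capped. In this assay compound 2 sits at a limit, > 100000 nM. Compound 4 `COc1ccc(C(=O)/C(=C/c2ccc([N+](=O)[O-])cc2)CC(C)C)cc1`, not yet measured, carries isopropyl in place of acetoxymethyl on a saturated chain carbon bound to a double-bonded chain carbon, the same change as from compound 1 to compound 3, made on the core of compound 2. The step is expected to be a step that the limit leaves unreadable from compound 2 to compound 4, resting on compound 3 at > 100000 nM and compound 2 already at a limit. Compound 4 is thus estimated at 150000 nM, within 60000 nM to 400000 nM, most likely reported only as a limit.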

Compound 4, half-maximal inhibitory concentration: > 100000 nM
Compound 4: a limit, no number (the forecaster's own chance of this, stated with the estimate: 80%); the middle value is on the limit's open side.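

In this assay compound 4 reaches only a limit, > 100000 nM. Among these compounds, compound 2 also sits at a limit, so no step from compound 2 to compound 4 can be read. The compounds shown leave open how compound 2, compound 3 and compound 4 compare with one another.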